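Chloro substitution on the anilide of compound 2

This account rests on a few compounds, and the source may have more. Where it says the series, first, only, none or still open, it means among the compounds named here.

Of the compounds shown here, two have been measured in a functional assay on BEL-7404 cells (Homo sapiens) for cytotoxicity, read by MTT assay, with a stated time of 72 h; a higher number here means a weaker inhibitor, a lower number a stronger inhibitor. Compound 1 `COCOc1ccc(/C=C/C(=O)N2CCN(Cc3ccc(Cl)c(Cl)c3)CC2)cc1OCOC` returns only a limit of the assay and not a number, > 200000 nM. Compound 2 `CCOc1ccc(COc2c(OC)cc(/C=C/C(=O)OCC(=O)Nc3ccccc3)cc2OC)cc1` likewise returns only a limit and not a number, > 200000 nM. Where compound 2 stands is therefore (the limit of > 200000 nM in this assay, at which 2 of the 2 values shown sit), and no step between measured compounds can be drawn from this pair.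

Compound 3 `CCOc1ccc(COc2c(OC)cc(/C=C/C(=O)OCC(=O)Nc3ccc(Cl)cc3)cc2OC)cc1` differs from compound 2 by chloro in place of hydrogen on an aromatic carbon, para to a large group. With both measured values sitting at the limit, no step size is available from which the effect of the added chloro could be read. In this assay nothing beyond the scatter is expected, and compound 3 is most likely to return a limit once more. The expected step is a step that the limit leaves unreadable from compound 2 to compound 3. The estimate for compound 3 is 250000 nM, within 50000 nM to 1000000 nM.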

Compound 3, half-maximal inhibitory concentration: > 200000 nM
Compound 3 was reported as a limit; the forecaster's own chance of this, stated with the estimate: 80%; the middle value lies beyond the limit too.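

Compound 3 gives > 200000 nM, a limit and not a number, so no step can be read from compound 2 to compound 3 in this assay. Still open is whether phenyl to 4-chlorophenyl changes cytotoxicity at all, and whether any compound shown reaches a measurable value: the limit of > 200000 nM in this assay, at which 3 of the 3 values shown sit.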